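Replacing 2-fluorophenyl with 3-nitrophenyl on compound 2

The source may report more compounds than this note shows. Statements on the series, on what has been measured and on what is new or still open speak of the compounds shown alone.

In a functional assay on MCF7 cells (Homo sapiens) for cytotoxicity, read by MTT assay, with a stated time of 96 h (on this read-out lower numbers stand for stronger inhibition and higher numbers for weaker inhibition), compound 1 (`COc1cc(C(=O)c2cn(-c3ccccc3)cc2-c2ccccc2Cl)cc(OC)c1OC`) gives 76 nM and compound 2 (`COc1cc(C(=O)c2cn(-c3cccc(C)c3)cc2-c2ccccc2F)cc(OC)c1OC`) gives 190 nM as the higher of the two numbers, a gap beyond the scatter. Going by the values given here, these two compounds differ in more than one place, and no measured step isolates a single change.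

Compound 3 (`COc1cc(C(=O)c2cn(-c3cccc(C)c3)cc2-c2cccc([N+](=O)[O-])c2)cc(OC)c1OC`) keeps the 3-methylphenyl group of compound 2 and carries 3-nitrophenyl in place of 2-fluorophenyl on an aromatic carbon. Among the compounds with values here, the data hold no measured precedent for this change, so the expectation is no step beyond the scatter, with the estimated step being a 1.3-fold higher number from compound 2 to compound 3 (0.12 log units; within the scatter) and either direction remaining open. The estimated value for compound 3 in this assay is 250 nM with an expected range from 50 nM to 1200 nM until a measurement is available.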

Compound 3, half-maximal inhibitory concentration: 880 nM
Compound 3: middle estimate off by 3.5-fold (0.55 log units), on the low side; the measured number falls inside the stated range.
By their numbers in this assay, from the lowest: compound 1; then compound 2; then compound 3.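

In this assay, the position on the five-membered aromatic ring, two ring bonds from the ring nitrogen, proves sensitive to its substituent: 3-nitrophenyl in place of 2-fluorophenyl gives a 4.6-fold higher number from compound 2 to compound 3 (0.67 log units; beyond the scatter). Compound 3 keeps the 3-methylphenyl group of compound 2, so this step isolates the change at this one position, which the comparison of compound 1 with compound 2 could not do. No measurement shown here accounts for the size of the step.

The compounds shown leave open whether the step follows the nitro group itself, the place of the substituent on the phenyl ring, or the departure of the fluorine. A 3-aminophenyl or 2-nitrophenyl group at this position would help separate these readings.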